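The source may report more compounds than this note shows. Statements on the series, on what has been measured and on what is new or still open speak of the compounds shown alone.

In a functional assay on HeLa cells (Homo sapiens) for inhibition, read by MTT assay, with a stated time of 4 days (on this read-out higher numbers stand for weaker inhibition and lower numbers for stronger inhibition), compound 2 `COc1cc(NC(C)CCCNC(=O)NNC(=O)NC(CO)(CO)CO)c2ncccc2c1` reaches only a limit of the assay, > 250000 nM. Within the data shown here, its one measured neighbour, compound 1 `COc1cc(NC(C)CCCNC(=O)NNC(=O)NCCCCCO)c2ncccc2c1`, likewise gives only a limit in this assay, >= 250000 nM. Among the measured compounds shown here, the single recorded step, a step that the two limits leave unreadable from compound 1 to compound 2, is therefore unreadable in size and direction, because both ends rest on limits (the limit of > 250000 nM in this assay, at which 1 of the 2 values shown sits, and (the limit of >= 250000 nM in this assay, at which 1 of the 2 values shown sits)). Compound 3 `COc1cc(NC(C)CCCNC(=O)Nc2ccc(Cl)c(C(F)(F)F)c2)c2ncccc2c1` is the unmeasured compound, and it differs from compound 2 in one place: 4-chloro-3-(trifluoromethyl)phenyl in place of ((2-hydroxy-1,1-bis(hydroxymethyl)ethyl)carbamoyl)amino on an amide-type nitrogen. For the measured compounds named here, no measured step resembles this change; the only comparison available exchanges one hydroxylated chain for another on the same nitrogen and says nothing about replacing the whole ((2-hydroxy-1,1-bis(hydroxymethyl)ethyl)carbamoyl)amino group by an aromatic ring. The expectation for compound 3 in this assay therefore rests on the structural change alone and carries wide uncertainty. Compound 3 is estimated at 10000 nM, with a range from 1500 nM to 80000 nM. That estimate would mean an expected step of an at least 25-fold lower number from compound 2 to compound 3 (1.39 log units; beyond the scatter) toward stronger inhibition, though a further limit cannot be ruled out.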

Compound 3, half-maximal inhibitory concentration: 3900 nM
Compound 3: middle estimate off by 2.6-fold (0.41 log units), on the high side; the range from low to high includes it.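

Among these compounds, on the amide-type nitrogen whose other neighbour is the carbonyl carbon, the entry of 4-chloro-3-(trifluoromethyl)phenyl yields the first number in this assay that is not a limit, with an at least 64-fold lower number from compound 2 to compound 3 (1.80 log units; beyond the scatter). The same group in place of ((5-hydroxypentyl)carbamoyl)amino gives an at least 64-fold lower number from compound 1 to compound 3 (1.80 log units; beyond the scatter), so at this position the outcome is the same whichever of the two hydroxylated groups leaves. From the compounds shown here alone, both steps start from a limit and therefore fix only a minimum size, and the true gap between the hydroxylated compounds and compound 3 stays unknown.

The compounds shown leave open which part of the entering group carries the step, as a plain phenyl ring, a 4-chlorophenyl or a 3-(trifluoromethyl)phenyl on the same nitrogen would separate the chlorine from the trifluoromethyl group. They also leave open whether the aromatic ring is needed at all or whether a long unbranched alkyl chain without a hydroxyl group, or a chain ending in an amine or a carboxylic acid, would bring a number of the same order.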